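Extending the aryl substituent in a cytotoxicity series

The compounds below may be only part of what the source reports. "The series", "measured", "known", "first", "only" and "open" are said of these compounds alone.

Compound 1 `CCCc1cc(-c2cn([C@H]3C[C@H](OC(C)=O)[C@@H](COC(C)=O)O3)c(=O)[nH]c2=O)on1` and compound 2 `CCc1ccc(-c2cc(-c3cn([C@H]4C[C@H](OC(C)=O)[C@@H](COC(C)=O)O4)c(=O)[nH]c3=O)on2)cc1` share a core and differ in the group on the aromatic carbon of the five-membered ring. In a functional assay on PC-3 cells (Homo sapiens) for cytotoxicity, read by sulforhodamine B assay, tested at 10 uM (on this read-out lower numbers stand for less inhibition and higher numbers for more inhibition at the one concentration tested (going by the name of the read-out)), compound 1 gives 88.1%. For the measured compounds named here, compound 2 gives 62.8% in this assay, which is the lower of the two numbers measured so far, and the step of a number 25.3 percentage points lower from compound 1 to compound 2 (beyond the scatter) lies beyond the scatter. Compound 3 `CC(=O)OC[C@H]1O[C@@H](n2cc(-c3cc(-c4ccc(C(C)C)cc4)no3)c(=O)[nH]c2=O)C[C@@H]1OC(C)=O` has not been measured; it differs from compound 2 by methyl in place of hydrogen on a saturated chain carbon bound to an aromatic carbon and a saturated chain carbon, so the 4-ethylphenyl group of compound 2 becomes a 4-isopropylphenyl group. Going by the values given here, the one measured step, from propyl to 4-ethylphenyl, concerns a different kind of change and gives no direct guide to adding a methyl to a saturated chain carbon. Among the compounds with values here, the only reference is the value of compound 2 itself. A step of about a number 2.8 percentage points lower from compound 2 to compound 3 (within the scatter) is therefore expected, which is within the scatter. Compound 3 is estimated to give 60% in this assay, with a range from 40% to 80%.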

Compound 3, a percentage reported as inhibition, at one concentration (the size of the read-out at that concentration, not a potency): 50.3%
Beside the measured number, compound 3's estimate is 9.7 percentage points above it, within the range that was stated.
By their numbers in this assay, from the lowest: compound 3; then compound 2; then compound 1.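

Going from the 4-ethylphenyl group to the 4-isopropylphenyl group gives a number 12.5 percentage points lower from compound 2 to compound 3 (beyond the scatter) in this assay, so one added methyl on a saturated chain carbon bound to an aromatic carbon and a saturated chain carbon is enough to move this read-out, a much smaller change than the earlier exchange of propyl for a whole 4-ethylphenyl group. Set against the propyl group, the 4-isopropylphenyl group gives a number 37.8 percentage points lower from compound 1 to compound 3 (beyond the scatter), a large step where the 4-ethylphenyl group gave a modest one, and across these three compounds the number falls as the group on the aromatic carbon gains carbons, with none of them going against that order. Nothing available here accounts for these steps.

The compounds shown leave open whether the fall continues with a tert-butyl group or a longer chain in place of the isopropyl, and whether a carboxylic acid or an amine at that same place would follow the same order. They also leave open how far these differences at one concentration in one cell line reflect differences in potency.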